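A few compounds are considered here, and "the series" means these few. Any claim that something is new, unique, unknown or untested is made for them only; others in the source may bear on it.

In a functional assay on A549 cells (Homo sapiens) for antiproliferative activity, read by MTT assay, with a stated time of 48 h (a lower number here means a stronger inhibitor, a higher number a weaker inhibitor), compound 1 `O=C(/C=C\Nc1ccc(C(F)(F)F)cc1)c1cn(-c2ccccc2)nc1-c1ccc(F)cc1` gives only a limit, > 50000 nM. Compound 2 `COc1ccc(N/C=C\C(=O)c2cn(-c3ccccc3)nc2-c2ccc(F)cc2)cc1` gives 8900 nM. Compound 3 `COc1cc(-c2nn(-c3ccccc3)cc2C(=O)/C=C\Nc2ccc(F)cc2)cc(OC)c1OC` gives 15600 nM, the higher of the two numbers, though its gap to compound 2 is within the scatter. Within the data shown here, the one measured step, an at least 5.6-fold lower number from compound 1 to compound 2 (0.74 log units; beyond the scatter), is known only as a bound because compound 1 sits at the limit of > 50000 nM in this assay, at which 1 of the 3 values shown sits. Compound 4 `COc1ccc(N/C=C\C(=O)c2cn(-c3ccccc3)nc2-c2cc(OC)c(OC)c(OC)c2)cc1` differs from compound 3 by methoxy in place of fluoro on an aromatic carbon. That step also brings in methoxy on the aniline ring, so a modest lowering of the number is expected, smaller than the measured step since fluoro, not trifluoromethyl, leaves. Compound 4 is therefore expected to give 7000 nM, between 2500 nM and 20000 nM. The expected step is a 2.2-fold lower number from compound 3 to compound 4 (0.35 log units; beyond the scatter).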

Compound 4, half-maximal inhibitory concentration: 4780 nM
The estimate for compound 4 lay 1.5-fold (0.17 log units) above the measured number; measured number inside the range.
By their numbers in this assay, from the lowest: compounds 4, 2 and 3 (each within the scatter of the next, the first and the last beyond it). At a limit, above all of these: compound 1.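

With 3,4,5-trimethoxyphenyl kept, (4-methoxyphenyl)amino in place of (4-fluorophenyl)amino brings a 3.3-fold lower number from compound 3 to compound 4 (0.51 log units; beyond the scatter), so methoxy at this place now has a step read between two real numbers. Compound 1, the earlier partner for methoxy, gives only a limit: the limit of > 50000 nM in this assay, at which 1 of the 4 values shown sits. By contrast, a 1.9-fold lower number from compound 2 to compound 4 (0.27 log units; within the scatter) stays within the scatter, so 3,4,5-trimethoxyphenyl in place of 4-fluorophenyl is not told apart here. On these data alone, whether an amine or a carboxylic acid at this place would match methoxy stays open. So does whether the methoxy step holds with 4-fluorophenyl in place of 3,4,5-trimethoxyphenyl.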